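The compounds below may be only part of what the source reports. "The series", "measured", "known", "first", "only" and "open" are said of these compounds alone.

Working notes on the series, cytotoxicity arm.

Compound 1 `CC(C)N(Cc1cccc(OCCCCCC(=O)O)c1)C(=O)c1ccc(-c2cccc(Cl)c2)cc1` carries the chloro-substituted phenyl on the shared core with a free acid on the chain. In an ADME assay on HepG2 cells (Homo sapiens) for cytotoxicity, read by CellTiter-Glo and resazurin assay, with a stated time of 72 h (on this read-out higher numbers stand for an effect only at larger amounts of compound and lower numbers for an effect already at smaller amounts), compound 1 gives only a limit, > 21900 nM, so no number is available for it. Compound 2 `CCOC(=O)CCCCCOc1cccc(CN(C(=O)c2ccc(-c3cccnc3)cc2)C(C)C)c1` has the ethyl ester on the chain and pyridin-3-yl on the core. In this assay compound 2 likewise gives only a limit, > 26000 nM. Both values of the pair shown thus sit at limits, as the lines the limit of > 21900 nM in this assay, at which 1 of the 2 values shown sits, and the limit of > 26000 nM in this assay, at which 1 of the 2 values shown sits, record, and compound 2 stands at one of them; nothing between the two measured compounds can be read as a step.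

Compound 3 `CCOC(=O)CCCCCOc1cccc(CN(C(=O)c2ccc(-c3cccc(-c4nnc(C)o4)c3)cc2)C(C)C)c1` keeps the ethyl ester of compound 2 and differs in one place: 3-(5-methyl-1,3,4-oxadiazol-2-yl)phenyl in place of pyridin-3-yl on an aromatic carbon. Within the data shown here, with both measured compounds at limits and no directional step to lean on, the step from compound 2 to compound 3 is expected to be none beyond the scatter, a number no higher from compound 2 to compound 3 (the limit leaves the size open), most likely again ending in a limit. Compound 3 is therefore estimated at 26000 nM in this assay, between 9000 nM and 60000 nM.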

Compound 3, half-maximal effective concentration: > 26000 nM
Compound 3 ended at the assay's limit; the forecaster's own chance of this, stated with the estimate: 75%; the middle value sits exactly at the limit.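

Compound 2 and compound 3 both end at a limit of the assay in this assay, so no step can be read between them: the limit of > 26000 nM in this assay, at which 2 of the 3 values shown sit.

The compounds shown leave open whether 3-(5-methyl-1,3,4-oxadiazol-2-yl)phenyl in place of pyridin-3-yl changes the read-out at all, and at what concentration compound 1, compound 2 or compound 3 would reach a half-maximal effect.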